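Amino addition on a thiophene and a furan nucleoside core

A few compounds are considered here, and "the series" means these few. Any claim that something is new, unique, unknown or untested is made for them only; others in the source may bear on it.

Within the data shown here, compound 1 `COc1ncnc2c1c(-c1ccsc1)cn2[C@@H]1O[C@H](CO)[C@@H](O)[C@H]1O` is the only compound here with a numerical result: in a functional assay on HCT-116 cells (Homo sapiens), read by MTT assay, with a stated time of 72 h (a higher number here means a weaker inhibitor, a lower number a stronger inhibitor), compound 1 gives 140 nM. Compound 2 `COc1nc(N)nc2c1c(-c1ccsc1)cn2[C@@H]1O[C@H](CO)[C@@H](O)[C@H]1O` carries the change (amino in place of hydrogen on an aromatic carbon), and its value in this assay is a limit of the assay, > 20000 nM. The step is an at least 140-fold higher number from compound 1 to compound 2 (2.15 log units; beyond the scatter), which is set by the limit of > 20000 nM in this assay, at which 2 of the 3 values shown sit. Compound 3 `O=c1[nH]cnc2c1c(-c1ccco1)cn2[C@@H]1O[C@H](CO)[C@@H](O)[C@H]1O` in this assay also reaches only a limit, > 20000 nM. How the core of compound 1 and the core of compound 3 differ is not broken down here. Compound 4 `Nc1nc2c(c(-c3ccco3)cn2[C@@H]2O[C@H](CO)[C@@H](O)[C@H]2O)c(=O)[nH]1` differs from compound 3 by amino in place of hydrogen on an aromatic carbon, the same kind of change as between compound 1 and compound 2, though the surroundings differ: meta to a group of 1 heavy atom rather than meta to a methoxy group (2 heavy atoms). Since compound 3 already sits at the limit and the amino group gave an at least 140-fold higher number from compound 1 to compound 2 (2.15 log units; beyond the scatter), compound 4 is expected to remain at or beyond that limit, an estimated step that the limit leaves unreadable from compound 3 to compound 4. Compound 4 is estimated at 40000 nM, within 20000 nM to 100000 nM.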

Compound 4, half-maximal inhibitory concentration: > 20000 nM
Compound 4 ended at the assay's limit; the forecaster's own chance of this, stated with the estimate: 90%; the middle value is on the limit's open side.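

Among these compounds, compound 3 and compound 4 both end at a limit, so no step between them can be read: the limit of > 20000 nM in this assay, at which 3 of the 4 values shown sit.

The compounds shown leave open whether amino in place of hydrogen changes anything on the core of compound 3.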